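From anilino to pyrrolidin-1-yl on a carbonyl carbon

The compounds below may be only part of what the source reports. "The series", "measured", "known", "first", "only" and "open" are said of these compounds alone.

Going by the values given here, in a functional assay on A549 cells (Homo sapiens) for inhibition, read by sulforhodamine B assay, with a stated time of 72 h (on this read-out higher numbers stand for weaker inhibition and lower numbers for stronger inhibition), compound 1 `Nc1sc(-c2ccc(Cl)cc2)c(-c2ccc(Cl)cc2)c1C(=O)Nc1ccccc1` gives 25000 nM as the only number available, so it cannot yet be ranked against anything. For compound 2 `CCN(CC)CCNC(=O)Nc1sc(-c2ccc(Cl)cc2)c(-c2ccc(Cl)cc2)c1C(=O)NC1CC1` the result reads "not determined" (no result reported). Compound 3 `Nc1sc(-c2ccc(Cl)cc2)c(-c2ccc(Cl)cc2)c1C(=O)N1CCCC1` keeps the core of compound 1 but carries pyrrolidin-1-yl in place of anilino on a carbonyl carbon, and pyrrolidin-1-yl in place of anilino on a carbonyl carbon sums up that swap. Among the compounds with values here, no measured step guides this change, so no direction can be favoured. The estimated step of a 1.1-fold lower number from compound 1 to compound 3 (0.06 log units; within the scatter) is expected to stay within the scatter in this assay and no larger. For compound 3 the estimated value is 22000 nM with an expected range from 7000 nM to 60000 nM around it.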

Compound 3, half-maximal inhibitory concentration: 890 nM
Beside the measured number, compound 3's estimate is 25-fold (1.39 log units) above it; measured number outside the range, below it.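

In this assay, the group on the carbonyl carbon clearly matters: pyrrolidin-1-yl in place of anilino gives a 28-fold lower number from compound 1 to compound 3 (1.45 log units; beyond the scatter), the first comparison available at this position. The swap removes a six-membered aromatic ring of carbon only and a hydrogen-bond donor together, so this single step cannot separate their contributions. No supporting measurement explains the size of the step.

From the compounds shown here alone, it remains open whether piperidin-1-yl, morpholin-4-yl or an open-chain diethylamino group on the same carbonyl carbon would match compound 3. A phenyl-bearing group such as benzylamino would help show what the aromatic ring contributes.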